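This account rests on a few compounds, and the source may have more. Where it says the series, first, only, none or still open, it means among the compounds named here.

Compound 1 `C#CCNC1CCc2c(SCCc3cccc(C)c3)cccc21` gives 0.35 nM in an assay on isolated protein for inhibition of Amine oxidase [flavin-containing] B (Homo sapiens) (on this read-out lower numbers stand for stronger inhibition and higher numbers for weaker inhibition), the lowest of the two numbers in hand. Among the measured compounds shown here, compound 2 `C#CCNC1CCc2c(SCc3ccc(Br)cc3)cccc21`, the only other measured member, gives 1310 nM in this assay, a far higher number, beyond the scatter. Compound 3 `C#CCNC1CCc2c(SCCc3cccc(Cl)c3)cccc21` differs from compound 1 by chloro in place of methyl on an aromatic carbon, meta to a large group. For the measured compounds named here, no measured pair shows this exchange, so its size is open; a move within the scatter, or a small one in either direction, appears most likely. For compound 3 the estimate in this assay is 0.5 nM, ranging from 0.15 nM to 2 nM. The expected step of a 1.4-fold higher number from compound 1 to compound 3 (0.15 log units; within the scatter) is taken to lie within the scatter.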

Compound 3, half-maximal inhibitory concentration: 82400 nM
Estimate against measurement, compound 3: 160000-fold (5.22 log units) below; measured number above the stated range.
By their numbers in this assay, from the lowest: compound 1; then compound 2; then compound 3.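

Chloro in place of methyl on this aromatic carbon, meta to a large group, is far from a neutral exchange in this assay: this change of one heavy atom gives a 240000-fold higher number from compound 1 to compound 3 (5.37 log units; beyond the scatter). Among the compounds shown here, the read-out at this position therefore depends sharply on which of these two groups is present, something the earlier compounds could not show. Nothing measured here accounts for the size of the step.

Still open, going by these compounds, is whether methyl is unusually favourable here or chloro unusually unfavourable. Hydrogen, fluoro, methoxy or an amine on the same carbon would help separate these two readings.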